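Pyrimidinyl for pyridinyl on a piperazine: an unread step

This account rests on a few compounds, and the source may have more. Where it says the series, first, only, none or still open, it means among the compounds named here.

Three amides built on the same piperazine linker have been tested in an assay on HEK293 cells for inhibition of sodium-dependent dopamine transporter (Homo sapiens), read by scintillation counting (a higher number here means a weaker inhibitor, a lower number a stronger inhibitor), and a fourth awaits its turn. Compound 1 `O=C(NCCCN1CCN(c2ccccn2)CC1)c1cc(Cl)cc(Cl)c1` carries a pyridin-2-yl group on the ring nitrogen and a dichlorinated benzamide. In this assay compound 1 reaches only the limit of the assay, > 10000 nM. Compound 2 `O=C(NCCCN1CCN(c2ncccn2)CC1)c1cc(Cl)cc(Cl)c1` differs from it in one place, (pyrimidin-2-yl in place of pyridin-2-yl on an amine nitrogen in a ring). In this assay compound 2 likewise stops at the limit, > 10000 nM. The step between them, a step that the two limits leave unreadable from compound 1 to compound 2, therefore cannot be sized. Compound 3 `O=C(NCCCN1CCN(c2ccccn2)CC1)c1ccc2ccccc2c1` keeps the pyridin-2-yl group of compound 1 on a different core; the difference between the two cores is not broken down here. In this assay compound 3 also returns only the limit, > 10000 nM. What the measured set shows is summed up by the limit of > 10000 nM in this assay, at which 3 of the 3 values shown sit, so none of the three gives a readable number.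

Compound 4 `O=C(NCCCN1CCN(c2ncccn2)CC1)c1ccc2ccccc2c1` is the unmeasured partner of compound 3, carrying the same change seen from compound 1 to compound 2, (pyrimidin-2-yl in place of pyridin-2-yl on an amine nitrogen in a ring). Because the limit of > 10000 nM in this assay, at which 3 of the 3 values shown sit, leaves the earlier step unreadable, the account expects the new step, a step that the limit leaves unreadable from compound 3 to compound 4, to be equally invisible at this limit. For compound 4 the estimate is 20000 nM, with an expected span from 8000 nM to 60000 nM, and most likely only another limit reported in this assay.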

Compound 4, half-maximal inhibitory concentration: > 10000 nM
Compound 4: no number, only a limit (the forecaster's own chance of this, stated with the estimate: 85%); the middle value lies beyond the limit too.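

In this assay, compound 3 and compound 4 both give only a limit and not a number, so the step between them cannot be read, and the set stays where it stood: the limit of > 10000 nM in this assay, at which 4 of the 4 values shown sit. The compounds shown leave open whether pyrimidin-2-yl and pyridin-2-yl differ at all in this assay, and how strongly any of these four amides inhibits the transporter.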